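The source may report more compounds than this note shows. Statements on the series, on what has been measured and on what is new or still open speak of the compounds shown alone.

Measured so far:
Compound 1 `COc1ccc(C2NC(=S)NC3=C2C(=O)CC(C)(C)C3)cc1` — 71%
Compound 2 `CC(=O)OC[C@H]1O[C@@H](SC2=NC3=C(C(=O)CC(C)(C)C3)C(c3ccc(Cl)cc3)N2)[C@H](OC(C)=O)[C@@H](OC(C)=O)[C@@H]1OC(C)=O` — 75%

Of the compounds shown here, two have been tested in a functional assay on the whole organism (strain Sprague-Dawley) with Rattus norvegicus as the target, read by paw edema, with stated times of 1 h and 4 h, at a dose of 70 mg/kg by the oral route; on this read-out higher numbers stand for more inhibition at the one dose given (going by the name of the read-out) and lower numbers for less inhibition. Compound 1 gives 71% there, and compound 2 gives 75%. Compound 2 holds the higher of the two numbers, but the nearest value, that of compound 1, lies within the usual scatter of it, so the two are not told apart by this read-out.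

The next compound is compound 3 `CC(=O)OC[C@H]1O[C@@H](SC2=NC3=C(C(=O)CC(C)(C)C3)C(c3ccc(Cl)cc3)N2)[C@H](OC(C)=O)[C@@H](OC(C)=O)[C@H]1OC(C)=O`. Its relation to compound 2 is this: the two compounds have the same atoms and bonds; at least one stereo element is drawn with a configuration in one of them and without one in the other: 1 of 6 stereo elements differ; a stereocentre at a saturated ring carbon is drawn R in compound 2 and S in compound 3. Nothing else changes. Within the data shown here, no pair of measured compounds differing in a single place has been tested, so there is no measured step of this kind to lean on. With the same atoms and bonds kept and only one drawn configuration at a saturated ring carbon altered, compound 3 is expected to stay close to compound 2, since compound 2 gives 75%. The expected step of a number 3 percentage points lower from compound 2 to compound 3 (within the scatter) is therefore no larger than the scatter, in no particular direction. Compound 3 is estimated to give about 72%, within a range from 58% to 84%.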

Compound 3, a percentage reported as inhibition, in the whole organism at one dose (the size of the read-out at that dose, not a potency): 76%
The estimate for compound 3 lay 4 percentage points below the measured number, and the stated range covers the measured number.
By their numbers in this assay, from the lowest: compounds 1, 2 and 3 (each within the scatter of the next).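

In this assay, altering one drawn configuration at a saturated ring carbon, from R to S, comes with a number 1 percentage points higher from compound 2 to compound 3 (within the scatter). Among these compounds, this is the first step that changes a single place, which the earlier compounds could not offer, and it gives no sign that this read-out, at its one dose, responds to the configuration at this position. The step is a limited test of that position, and any reading of it as a clean exchange of one defined configuration for another has to carry one reservation: the fact that one of compounds 2 and 3 is drawn with a defined configuration and the other without, at the place where they differ

The compounds shown leave open whether the same insensitivity holds at the other stereo elements, or at other doses, where a difference hidden by a single-dose percentage might appear. They also leave open how the read-out would respond if the acetate esters gave way to free hydroxyl groups, or if the chlorophenyl group carried a carboxylic acid or an amine, since every change so far keeps the atoms and bonds of the series' two closest members intact.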